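The source may hold more compounds than are shown below. What is called first, only, known or untested is meant among the compounds shown, and "the series" means these compounds.

- compound 1 `CC1(C)C=C(c2cc(-c3ccc(F)cc3Cl)c3ccc(=O)n(-c4c(Cl)cccc4Cl)c3c2)CC(C)(C)N1`: 36%
- compound 2 `CC(C)(C)N1CCC(c2cc(-c3ccc(F)cc3Cl)c3ccc(=O)n(-c4c(Cl)cccc4Cl)c3c2)CC1`: 47.7%

Within the data shown here, in an in vivo ADME assay on the whole organism for pharmacokinetics, with Rattus norvegicus as the target (a lower number here means that a smaller share of the oral dose reaches the circulation, a higher number that a larger share of the oral dose reaches the circulation), compound 2 stands highest of the two at 47.7% and the only measured step is a number 11.7 percentage points higher from compound 1 to compound 2 (beyond the scatter) in the six-membered non-aromatic ring group. Compound 3 `CC(C)(C)N1CCC(c2cc(-c3ccc(F)cc3F)c3ccc(=O)n(-c4c(Cl)cccc4Cl)c3c2)CC1` differs elsewhere: fluoro in place of chloro on an aromatic carbon, turning 2-chloro-4-fluorophenyl into 2,4-difluorophenyl. Among the measured compounds shown here, no measured pair makes this change, so the one step gives no direct size for it. The expected step in this assay is a number 1.7 percentage points lower from compound 2 to compound 3 (within the scatter) and nothing beyond the scatter is expected in either direction. Compound 3 is estimated at 46% with an expected range from 32% to 60%.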

Compound 3, oral bioavailability: 69.3%
For compound 3 the middle estimate is 23.3 percentage points below the measured one; the measured number lies above the stated range.
By their numbers in this assay, from the lowest: compound 1; then compound 2; then compound 3.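

In this assay, the place held by chloro on the 2-chloro-4-fluorophenyl group matters: fluoro in place of chloro, one heavy atom for another, gives a number 21.6 percentage points higher from compound 2 to compound 3 (beyond the scatter). Among these compounds, the earlier step touched only the six-membered non-aromatic ring, so this is the first sign that the six-membered aromatic ring also counts for this read-out. Nothing available explains the gain. As far as these compounds go, whether a methyl or methoxy group at this place would do better or worse stays open. So does whether fluoro would bring a similar gain with the ring of compound 1.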